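The source may report more compounds than this note shows. Statements on the series, on what has been measured and on what is new or still open speak of the compounds shown alone.

The account concerns two measured compounds and one still untested, all built on the shared core of compound 1 `CS(=O)(=O)Nc1cccc2c1CCC2c1ncc[nH]1`. In a functional assay on CHO cells for agonist activity at Alpha-1D adrenergic receptor (Homo sapiens), read by FLIPR and calcium flux (a higher number here means that more compound is needed for the effect, a lower number that less compound is needed), compound 1 gives > 10000 nM, which is a limit of the assay and not a number. Compound 2 `COc1c(Cl)ccc2c1CCC2c1ncc[nH]1` carries other groups on the same core. In this assay compound 2 gives > 10000 nM, likewise a limit rather than a measured value. Among the measured compounds shown here, compound 1 therefore stands at the limit of > 10000 nM in this assay, at which 2 of the 2 values shown sit, and no measured step between compounds has been determined, so no size or direction of change can be read from the data themselves. The untested compound 3 `c1cncc(-c2cccc3c2CCC3c2ncc[nH]2)c1` is reached from compound 1 by one change: pyridin-3-yl in place of methanesulfonamido on an aromatic carbon. For the measured compounds named here, because both measured values sit at the limit of > 10000 nM in this assay, at which 2 of the 2 values shown sit, no measured step offers guidance, and the expected step from compound 1 to compound 3 in this assay, an at least 1.1-fold lower number from compound 1 to compound 3 (0.04 log units; that floor lies within the scatter), is estimated as no real change beyond the scatter. The value expected for compound 3 in this assay is 9000 nM, with a range estimated from 1500 nM to 30000 nM.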

Compound 3, half-maximal effective concentration: > 10000 nM
Compound 3 ended at the assay's limit; the forecaster's own chance of this, stated with the estimate: 60%; middle value at least 1.1-fold (0.04 log units) away from the limit.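

In this assay compound 3 gives > 10000 nM as a limit of the assay and not a number. Among the compounds shown here, no step between compound 1 and compound 3 can be read, because both stand at a limit: the limit of > 10000 nM in this assay, at which 3 of the 3 values shown sit. The compounds shown leave open whether pyridin-3-yl and methanesulfonamido differ in effect, and whether any compound on the shared core reaches a measurable value in this assay.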